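This account rests on a few compounds, and the source may have more. Where it says the series, first, only, none or still open, it means among the compounds named here.

Measured so far in an ADME assay on cells for inhibition of cytochrome P450 11B1, mitochondrial (Homo sapiens), read by HTRF, with stated times of 1 h and 3 h; on this read-out higher numbers stand for weaker inhibition and lower numbers for stronger inhibition:
Compound 1 `CC(C)(O)c1cncc(-n2ncc3ccccc32)c1` gives 535 nM.
Compound 2 `CC(C)(O)c1cncc(-n2ncc3c(F)cccc32)c1` gives 149 nM.

Among the measured compounds shown here, compound 2 stands lowest of the two numbers; the only step measured so far is a 3.6-fold lower number from compound 1 to compound 2 (0.56 log units; beyond the scatter). Compound 3 `Cc1cccc2c1cnn2-c1cncc(C(C)(C)O)c1` differs from compound 2 by methyl in place of fluoro on an aromatic carbon, on an aromatic carbon of a six-membered aromatic ring of carbon only, part of a fused system of two rings. On these data alone, that one step bears on this only indirectly: it shows that fluoro in place of hydrogen at this carbon gave a modest drop, but whether methyl keeps that gain is unknown, so in this assay a step within the scatter or a modest rise is expected. Compound 3 is therefore estimated at 220 nM (range 80 nM to 600 nM), meaning an expected step of a 1.5-fold higher number from compound 2 to compound 3 (0.17 log units; within the scatter).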

Compound 3, half-maximal inhibitory concentration: 210 nM
The estimate for compound 3 lay 1.0-fold (0.02 log units) above the measured number, within the range that was stated.
By their numbers in this assay, from the lowest: compounds 2 and 3 (each within the scatter of the next); then compound 1.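

In this assay, fluoro is not the only replacement for hydrogen at this carbon that lowers the number: methyl in place of hydrogen gives a 2.5-fold lower number from compound 1 to compound 3 (0.41 log units; beyond the scatter) and so also stands beyond the scatter. Methyl in place of fluoro gives a 1.4-fold higher number from compound 2 to compound 3 (0.15 log units; within the scatter) and stays within the scatter, so the two groups cannot be told apart here. Nothing on hand explains either step.

On these data alone, whether chloro, ethyl, methoxy or an amine at this carbon would give a similar number remains open. So does whether fluoro or methyl would act alike on the other carbons of this ring.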